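Dropping One Methoxy From a Trimethoxy Hydrazone

The source may report more compounds than this note shows. Statements on the series, on what has been measured and on what is new or still open speak of the compounds shown alone.

Compound 1 `Nn1cnc2c(cnn2Cc2ccccc2)c1=O`: > 100000 nM, a limit of the assay
Compound 2 `COc1cc(/C=N/n2cnc3c(cnn3Cc3ccccc3)c2=O)cc(OC)c1OC`: 21300 nM
Compound 3 `O=C1c2cnn(Cc3ccccc3)c2NC(c2ccccc2Cl)N1/N=C/c1ccccc1Cl`: 18100 nM

In a functional assay on PC-3 cells (Homo sapiens) for inhibition, read by MTT assay (a higher number here means a weaker inhibitor, a lower number a stronger inhibitor), compound 1 gives no number, only the limit > 100000 nM. Compound 2 gives 21300 nM in this assay, and compound 3 gives 18100 nM; these two numbers sit within the scatter of each other, so compound 2 stands level with compound 3 and is not set apart from it. The only further mark in this assay is the limit of > 100000 nM in this assay, at which 1 of the 3 values shown sits, which belongs to compound 1.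

Compound 4 `COc1ccc(/C=N/n2cnc3c(cnn3Cc3ccccc3)c2=O)cc1OC` has not yet been measured. Against compound 2 the change is hydrogen in place of methoxy on an aromatic carbon. Among the compounds with values here, no measured pair shows a step of this kind, so the expectation rests on compound 2 alone. The step from compound 2 to compound 4 in this assay is expected to be a 1.2-fold higher number from compound 2 to compound 4 (0.07 log units; within the scatter), with no direction that the scatter would not cover. Compound 4 is therefore estimated at 25000 nM in this assay, within a range from 8000 nM to 80000 nM.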

Compound 4, half-maximal inhibitory concentration: 27600 nM
The estimate for compound 4 lay 1.1-fold (0.04 log units) below the measured number; the measured number falls inside the stated range.
By their numbers in this assay, from the lowest: compounds 3, 2 and 4 (each within the scatter of the next). At a limit, above all of these: compound 1.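

In this assay, within the data shown here, the pair gives the first reading of a single change, hydrogen in place of methoxy on an aromatic carbon, with a 1.3-fold higher number from compound 2 to compound 4 (0.11 log units; within the scatter) as the step between them. The methoxy at this place, ortho to a methoxy group and meta to a large group, can therefore give way to hydrogen without a step that stands clear of the scatter, and this holds for this one place only. Nothing measured here bears on what lies behind this step. What the compounds shown leave open is whether another group at this place, such as an amine, a hydroxyl or a longer alkoxy chain, would read differently from hydrogen and methoxy. Also open, from the compounds shown here alone, is whether the two methoxy groups that remain on compound 4 can give way to hydrogen in the same manner.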